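The source may report more compounds than this note shows. Statements on the series, on what has been measured and on what is new or still open speak of the compounds shown alone.

Measured compounds:
Compound 1, `Cc1ccccc1-c1cc(C(=O)N2CCC3(CC2)CC(=O)c2nn(C(C)(C)C)cc2O3)c2ccccc2n1`. In a functional assay on HepG2 cells (Homo sapiens) for inhibition, read by MTT assay, with a stated time of 72 h (a lower number here means a stronger inhibitor, a higher number a weaker inhibitor), compound 1 gives > 10000 nM, which is a limit of the assay, not a number.
Compound 2, `CC(C)(C)n1cc2c(n1)C(=O)CC1(CCN(C(=O)c3cc(-c4ccccc4Cl)nc4ccccc34)CC1)O2`. In this assay compound 2 gives > 10000 nM, again a limit of the assay.
Compound 3, `Cc1cc(C(=O)N2CCC3(CC2)CC(=O)c2nn(C(C)(C)C)cc2O3)c2ccccc2n1`. In this assay compound 3 gives 9480 nM.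

Compound 3 is the only one of the three with a number; the other two sit at the limit of > 10000 nM in this assay, at which 2 of the 3 values shown sit. The core of compound 3 differs from that of compound 1 by methyl in place of 2-methylphenyl on an aromatic carbon. The step is an at least 1.0-fold lower number from compound 1 to compound 3 (0.02 log units; that floor lies within the scatter), and from the other side an at least 1.0-fold lower number from compound 2 to compound 3 (0.02 log units; that floor lies within the scatter). Both floors lie within the scatter, so no order among the three can be read.

The change from compound 1 to compound 2 is chloro in place of methyl on an aromatic carbon. Its step, a step that the two limits leave unreadable from compound 1 to compound 2, stays unreadable because both values sit at the limit of > 10000 nM in this assay, at which 2 of the 3 values shown sit.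

Compound 4, `CC(C)(C)n1cc2c(n1)C(=O)CC1(CCN(C(=O)c3cc(Cl)nc4ccccc34)CC1)O2`, is not yet measured and differs from compound 3 by chloro in place of methyl on an aromatic carbon. This is the same kind of change as from compound 1 to compound 2, not the same: there the place was on an aromatic carbon of a six-membered aromatic ring of carbon only, ortho to a large group; here it is on an aromatic carbon of a six-membered aromatic ring with 1 nitrogen, part of a fused or bridged system of two rings, next to the ring nitrogen, meta to a fused ring, meta to a large group, para to a fused ring.

Among the measured compounds shown here, the one measured instance of this kind of change gives no readable size, so the expectation rests on compound 3 alone, whose value 9480 nM lies close to the limit of > 10000 nM in this assay, at which 2 of the 3 values shown sit. In this assay the expected step is a 1.1-fold lower number from compound 3 to compound 4 (0.02 log units; within the scatter). Compound 4 is therefore estimated at 9000 nM, with a range from 3000 nM to 25000 nM, and a real chance that the assay returns only a limit.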

Compound 4, half-maximal inhibitory concentration: 4720 nM
Compound 4: middle estimate off by 1.9-fold (0.28 log units), on the high side, and the stated range covers the measured number.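

In this assay the step is a 2.0-fold lower number from compound 3 to compound 4 (0.30 log units; within the scatter), so on this core chloro in place of methyl gives no difference that can be told from the scatter, and it shows neither a gain nor a loss. The same kind of change on the other ring, between compound 1 and compound 2, cannot be read, so there is no second size to set beside this one, and nothing shows whether the change carries from one core to another: the limit of > 10000 nM in this assay, at which 2 of the 4 values shown sit. The two steps beyond the scatter, an at least 2.1-fold lower number from compound 2 to compound 4 (0.32 log units; beyond the scatter) and an at least 2.1-fold lower number from compound 1 to compound 4 (0.32 log units; beyond the scatter), belong to a different change, chloro in place of 2-chlorophenyl or 2-methylphenyl, and each gives only a floor on the size of the step, so they say nothing about chloro against methyl.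

The compounds shown leave open what other small groups would do at this place on the ring with 1 nitrogen, such as an amine, a methoxy group or a carboxylic acid. They also leave open how far the number can fall in this series, since compound 4, the lowest number shown, gives 4720 nM, which is still a weak value in this cell assay.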